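The compounds below may be only part of what the source reports. "The series", "measured", "known", "first", "only" and "open" are said of these compounds alone.

Compound 1 `O=C1CNC(=O)N1C[C@H]1CN(c2ccc(-n3cc(-c4ccccn4)cn3)c(F)c2)C(=O)O1` and compound 2 `COC[C@H]1CN(c2ccc(-n3cc(-c4ccccn4)cn3)c(F)c2)C(=O)O1` share the same core and differ in a single place. In an ADME assay on HEK293-A cells (Homo sapiens) for cytotoxicity, read by MTT assay, with a stated time of 48 h (a lower number here means a stronger inhibitor, a higher number a weaker inhibitor), compound 1 gives > 400 ug/mL, which is a limit of the assay rather than a number. In this assay compound 2 gives > 400 ug/mL, again a limit. The step that the two limits leave unreadable from compound 1 to compound 2 is therefore not readable, both values sitting at the limit of > 400 ug/mL in this assay, at which 2 of the 2 values shown sit. Compound 2 thus stands only at a limit, with no number of its own.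

Compound 3 `O=C1O[C@@H](CNC(=O)C(F)(F)F)CN1c1ccc(-n2cc(-c3ccccn3)cn2)c(F)c1` differs from compound 2 by ((trifluoromethyl)carbonyl)amino in place of methoxy on a saturated chain carbon bound to a saturated ring carbon. No measured step bears on this change, and the single step shown is unreadable. The expected step is a number no higher from compound 2 to compound 3 (the limit leaves the size open), with nothing beyond the scatter. Compound 3 is expected to give 400 ug/mL in this assay, within 200 ug/mL to 800 ug/mL, most likely reported once more as a limit.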

Compound 3, half-maximal inhibitory concentration: > 400 ug/mL
Compound 3: no number, only a limit; the forecaster's own chance of this, stated with the estimate: 80%; the middle value lies on the limit itself.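

The steps among compound 1, compound 2 and compound 3 in this assay cannot be read: the limit of > 400 ug/mL in this assay, at which 3 of the 3 values shown sit.

Still open, as far as these compounds go, is whether any group at this place on the saturated chain carbon changes the value in this assay; none of the three compounds has a number of its own.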